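This account rests on a few compounds, and the source may have more. Where it says the series, first, only, none or still open, it means among the compounds named here.

In a functional assay on RPMI-8226 cells (Homo sapiens) for cytotoxicity, read by MTT assay, with a stated time of 48 h (a lower number here means a stronger inhibitor, a higher number a weaker inhibitor), compound 1 `C#CCOC(=O)NN=C1C(Cl)=C(Cl)C(Cl)=C1Cl` gives 800 nM, the higher of the two actual numbers in the series. Compound 2 `FC(F)(F)c1cccc(NN=C2C(Cl)=C(Cl)C(Cl)=C2Cl)c1` gives 110 nM, lower than compound 1 by more than the scatter. Compound 3 `CC(C)(C)NN=C1C(Cl)=C(Cl)C(Cl)=C1Cl` stands at > 3000 nM, which is a limit of the assay and not a number. Compound 4 `CC(C)(C)C(=O)NN=C1C(Cl)=C(Cl)C(Cl)=C1Cl` departs from compound 1 by one change on a carbonyl carbon: tert-butyl in place of propargyloxy, (tert-butyl in place of propargyloxy on a carbonyl carbon). Among the measured compounds shown here, no measured pair shows this change, so only a small weakening is expected in this assay, possibly not beyond the scatter. The expected step is a 1.3-fold higher number from compound 1 to compound 4 (0.10 log units; within the scatter). For compound 4 the estimate is 1000 nM, with an expected range of 300 nM to 3000 nM.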

Compound 4, half-maximal inhibitory concentration: 90 nM
Beside the measured number, compound 4's estimate is 11-fold (1.05 log units) above it, and the stated range ends above it.
By their numbers in this assay, from the lowest: compounds 4 and 2 (each within the scatter of the next); then compound 1. At a limit, above all of these: compound 3.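

In this assay, the carbonyl carbon bound to the amide-type nitrogen proves sensitive to its substituent: tert-butyl in place of propargyloxy gives an 8.9-fold lower number from compound 1 to compound 4 (0.95 log units; beyond the scatter), a clear step. Both groups hold 4 heavy atoms, so a large change here comes without a change in that count. Nothing measured here assigns a cause to this step.

As far as these compounds go, whether the step follows from the tert-butyl itself or from the loss of the propargyloxy stays open. How an amine or a longer chain on the same carbonyl carbon would read is also unknown.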